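Hydroxyguanidine hydrazones: cytotoxicity series, toward compound 4

This account rests on a few compounds, and the source may have more. Where it says the series, first, only, none or still open, it means among the compounds named here.

Compounds share a hydroxyguanidine hydrazone core with a varied benzene ring: compound 1 `N=C(NO)N/N=C/c1ccccc1Cl`, compound 2 `CN(C)c1ccc(/C=N/NC(=N)NO)cc1`, compound 3 `Cc1ccccc1/C=N/NC(=N)NO` and the unmeasured compound 4 `Cc1ccc(/C=N/NC(=N)NO)cc1`. In an ADME assay on HeLa cells (Homo sapiens) for cytotoxicity (on this read-out higher numbers stand for lower toxicity in this test and lower numbers for higher toxicity in this test), compound 1 shows only a limit, > 100000 nM. Compound 3 likewise gives only a limit in this assay, > 100000 nM. For compound 2 this assay reports only a limit as well, > 100000 nM, so compound 2 stands at the limit of > 100000 nM in this assay, at which 3 of the 3 values shown sit. The step that the two limits leave unreadable from compound 1 to compound 3 is unreadable. The change to compound 4 is methyl in place of dimethylamino on an aromatic carbon. Among the compounds with values here, no measured step reads on it; all three values sit at the limit, so no step beyond the scatter is expected. Compound 4 is estimated at 100000 nM (range 50000 nM to 200000 nM). The expected step is a number no higher from compound 2 to compound 4 (the limit leaves the size open), within the scatter.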

Compound 4, half-maximal cytotoxic concentration: > 100000 nM
Compound 4 was reported as a limit; the forecaster's own chance of this, stated with the estimate: 80%; the middle value sits exactly at the limit.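

Compound 2 and compound 4 are both reported only as limits, so no new step can be read between them. The compounds shown leave open where any half-maximal cytotoxic concentration lies and whether any aromatic substituent changes it.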